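The compounds below may be only part of what the source reports. "The series", "measured", "known", "first", "only" and "open" are said of these compounds alone.

Measured so far:
compound 1 `COc1cc(Cl)cc(-c2nn(-c3cccc(NC(=O)Nc4ccc(Cl)c(C(F)(F)F)c4)c3)cc2-c2ccncc2)c1` gives -22.6% in a functional assay on OVCAR-3 cells (Homo sapiens) for inhibition, read by sulforhodamine B assay, with a stated time of 48 h, tested at 10 uM; a higher number here means a weaker effect of the compound at the concentration tested, a lower number a stronger effect;
compound 2 `COc1cc(Cl)cc(-c2nn(-c3cccc(NC(=O)Nc4cc(C(F)(F)F)cc(C(F)(F)F)c4)c3)cc2-c2ccncc2)c1` gives -1.62% in this assay;
compound 3 `COc1cc(Cl)cc(-c2nn(-c3cccc(NC(=O)Nc4ccc(Cl)c(Cl)c4)c3)cc2-c2ccncc2)c1` gives 4.11% in this assay.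

Compound 3 has the highest number of the three; compound 2 lies within the scatter of it, and compound 1 sits further off. Compound 4 `COc1cc(Cl)cc(-c2nn(-c3cccc(NC(=O)Nc4cccc(C(F)(F)F)c4)c3)cc2-c2ccncc2)c1` differs from compound 3 by 3-(trifluoromethyl)phenyl in place of 3,4-dichlorophenyl on an amide-type nitrogen. For the measured compounds named here, the only measured step touching a trifluoromethyl group is a number 26.7 percentage points higher from compound 1 to compound 3 (beyond the scatter), but no two measured compounds differ by the same change as compound 3 to compound 4. Compound 1 and compound 2 both carry a trifluoromethyl group and both read lower than compound 3, so a small fall, likely within the scatter, is expected: a number 8.1 percentage points lower from compound 3 to compound 4 (within the scatter). Compound 4 is estimated at -4%, between -25% and 14%.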

Compound 4, a percentage reported as activity, at one concentration (the size of the read-out at that concentration, not a potency): -0.41%
The estimate for compound 4 lay 3.6 percentage points below the measured number; low and high end bracket the measured number.
By their numbers in this assay, from the lowest: compound 1; then compounds 2, 4 and 3 (each within the scatter of the next).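

In this assay, 3-(trifluoromethyl)phenyl in place of 3,4-dichlorophenyl on the amide-type nitrogen gives a number 4.5 percentage points lower from compound 3 to compound 4 (within the scatter) and so shows no real change at this position. Losing a trifluoromethyl group likewise gives only a number 1.2 percentage points higher from compound 2 to compound 4 (within the scatter), while hydrogen in place of chloro gives a number 22.2 percentage points higher from compound 1 to compound 4 (beyond the scatter) and is the only one of these steps beyond the scatter. It shows that the chloro matters when it sits on the ring with a trifluoromethyl group, as in compound 1.

No measurement here explains that step. As far as these compounds go, whether an amine or a nitrile on this ring would read like the chloro remains open.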